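The source may hold more compounds than are shown below. What is called first, only, known or untested is meant among the compounds shown, and "the series" means these compounds.

Measured so far:
compound 1 `COc1ccccc1N1C(=O)CSC1c1cc(F)cc(C(=O)O)c1` — 0%
compound 2 `COc1ccc(C)cc1N1C(=O)CSC1c1cccc(C(=O)NCCCCc2ccccc2)c1` — 79%

In a functional assay on SJSA-1 cells (Homo sapiens) for inhibition, read by CCK-8 assay, with a stated time of 72 h, tested at 1 uM (on this read-out higher numbers stand for more inhibition at the one concentration tested (going by the name of the read-out) and lower numbers for less inhibition), compound 1 gives 0%, and compound 2 gives 79%. Compound 2 stands highest of the two numbers shown; its nearest neighbour, compound 1, lies lower by a gap beyond the scatter. For the measured compounds named here, the two differ in more than one place, so no single step is recorded between them and only the two values themselves can be set side by side.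

Compound 3 `COc1ccc(OC)c(N2C(=O)CSC2c2cccc(C(=O)NCCCCc3ccccc3)c2)c1` has not yet been measured in this assay. It differs from compound 2 in one place: methoxy in place of methyl on an aromatic carbon; cut one bond further out, 2-methoxy-5-methylphenyl becomes 2,5-dimethoxyphenyl, the site being meta to a large group and para to a methoxy group. Going by the values given here, no measured pair isolates this change, so its size is uncertain. The expected step from compound 2 to compound 3 is small and downward, or none beyond the scatter, a number 9 percentage points lower from compound 2 to compound 3 (within the scatter). Compound 3 is estimated at 70%, within 45% to 90%.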

Compound 3, a percentage reported as inhibition, at one concentration (the size of the read-out at that concentration, not a potency): 48%
Compound 3: the middle estimate sits 22 percentage points above what was measured; measured number inside the range.
By their numbers in this assay, from the lowest: compound 1; then compound 3; then compound 2.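

In this assay, the aromatic carbon meta to a large group and para to a methoxy group proves sensitive to what it carries. Methoxy in place of methyl there gives a number 31 percentage points lower from compound 2 to compound 3 (beyond the scatter), the first change in the series that can be read at a single place. The read-out is reduced rather than lost, with compound 3 still at 48% at the one concentration tested, and no measurement on hand accounts for the step.

From the compounds shown here alone, only methyl and methoxy have been seen at this site, so it remains open how a chlorine, a hydroxyl or an amine would read there. Also open, going by these compounds, is whether the same exchange gives a step of similar size with a shorter chain on the amide.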